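Solubility notes: compound 1 and its epimer compound 4

The compounds below may be only part of what the source reports. "The series", "measured", "known", "first", "only" and "open" are said of these compounds alone.

The series is followed in a physicochemical assay for solubility, measured as kinetic solubility; a lower number here means a less soluble compound, a higher number a more soluble compound. For the measured compounds named here, compound 1 `Cc1cc(C)c(CN2CCc3c(Cl)cc([C@@H](CO)[C@@H]4CCCO4)c(Cl)c3C2=O)c(=O)[nH]1` gives 550000 nM in this assay, the only single number it has there; two further entries of compound 1 carry no single number. Two related compounds sit in the same region: compound 2 `COC(c1cc(Cl)c2c(c1Cl)C(=O)N(Cc1c(C)cc(C)[nH]c1=O)CC2)C1CCN(C2COC2)CC1` gives 523000 nM; 519000 nM (2 entries) in this assay, and compound 3 `COC(c1cc(Cl)c2c(c1Cl)C(=O)N(Cc1c(C)cc(C)[nH]c1=O)CC2)C1CCN(C(C)=O)CC1` gives 532000 nM; 498000 nM (2 entries) in this assay. The repeated entries show how closely this assay repeats itself here: the several entries of compound 2 in this assay, 523000 nM; 519000 nM (2 entries) and (the several entries of compound 3 in this assay, 532000 nM; 498000 nM (2 entries)), each pair within the usual scatter. Going by the values given here, no step between two measured compounds that differ in one place is available, so nothing measured says how much a single change moves the number in this assay.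

Compound 4 `Cc1cc(C)c(CN2CCc3c(Cl)cc([C@H](CO)[C@@H]4CCCO4)c(Cl)c3C2=O)c(=O)[nH]1` is not yet measured. It differs from compound 1 as follows: the two compounds have the same atoms and bonds and differ only in configuration as drawn: 1 of 2 stereo elements differ; a stereocentre at a saturated chain carbon is drawn S in compound 1 and R in compound 4. The atoms and bonds are unchanged. Given that compound 1 gives 550000 nM and that compound 2 and compound 3 lie at the same level, no step beyond the scatter is expected from compound 1 to compound 4 in this assay. The estimate for compound 4 is 520000 nM in this assay, within 300000 nM to 800000 nM. The step this estimate means is expected to stay within the scatter: a 1.1-fold lower number from compound 1 to compound 4 (0.02 log units; within the scatter).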

Compound 4, solubility: 400000 nM
The estimate for compound 4 lay 1.3-fold (0.11 log units) above the measured number, and the stated range covers the measured number.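

For the compounds shown here, changing the stereocentre at the saturated chain carbon, drawn S in compound 1 and R in compound 4, gives the only single-place step available in this assay: a 1.4-fold lower number from compound 1 to compound 4 (0.14 log units; within the scatter). This step is within the scatter, so the measured numbers do not separate the two configurations at this carbon, and neither compound can be placed above the other. The step reads as a change of configuration alone, with no other structural change mixed into it: the fact that compounds 1 and 4 differ only in the configuration as drawn

The pair says nothing about how this assay responds when the group itself is changed, for instance when a carboxylic acid or an amine takes the place of the chain at this carbon. The second stereo element, which is the same in compound 1 and compound 4, also remains open, so the effect of changing its configuration, alone or together with the first, cannot be read from the compounds shown.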